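Shortening the chain on the core of compound 2

The compounds below may be only part of what the source reports. "The series", "measured", "known", "first", "only" and "open" are said of these compounds alone.

Measured so far:
compound 1, `C=CCn1c(=O)n(CCC(CCOCc2ccccc2)CCOCc2ccccc2)c2nc(N)nc(O)c21`, 68%
compound 2, `CCCCCCCCCCn1c(=O)n(C2OC(CO)[C@@H](O)[C@H]2O)c2nc(N)nc(O)c21`, 0%

Of the compounds shown here, two that share a core have been measured in a functional assay on the whole organism (B cells) with Mus musculus as the target; on this read-out lower numbers stand for smaller maximal responses and higher numbers for larger maximal responses. Compound 1 carries an allyl group and a chain bearing two benzyloxy groups; in this assay compound 1 gives 68%. Compound 2 carries a decyl group and a sugar; in this assay compound 2 gives 0%. Compound 2 thus stands lowest of the two numbers, and its nearest neighbour, compound 1, lies a long way above it, beyond the scatter. Because the two differ in more than one place, their gap says nothing about any single change.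

Compound 3, `CCCCn1c(=O)n(C2OC(CO)[C@@H](O)[C@H]2O)c2nc(N)nc(O)c21`, is not yet measured. It differs from compound 2 in one place: hydrogen in place of hexyl on a saturated chain carbon, four bonds along the chain from an aromatic nitrogen. Among the compounds with values here, no step of this kind is known among the measured compounds, so the direction rests on compound 2 alone. Since compound 2 gives 0%, the number can only rise or stay; compound 3 is expected to rise by a number 40 percentage points higher from compound 2 to compound 3 (beyond the scatter). Compound 3 is therefore estimated at 40%, within 5% to 80%.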

Compound 3, largest response reached (reported as maximal response), in percent of the reference or control that the assay uses: 86%
The estimate for compound 3 lay 46 percentage points below the measured number; the measured number lies above the stated range.
By their numbers in this assay, from the lowest: compound 2; then compound 1; then compound 3.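

In this assay, hydrogen in place of hexyl on a saturated chain carbon, four bonds along the chain from an aromatic nitrogen, gives a number 86 percentage points higher from compound 2 to compound 3 (beyond the scatter). Within the data shown here, this is the first comparison that isolates a single place, and it shows that the length of this chain alone, with the sugar and the shared core unchanged, can carry the read-out from the bottom of the measured numbers to the top of them. Nothing at hand bears on why the shorter chain behaves in this way.

The compounds shown leave open how the number behaves at this place for a chain of intermediate length such as hexyl, for a shorter one such as propyl, and for a chain ending in an amine or a carboxylic acid. They also leave open whether the allyl group of compound 1 would hold up on the sugar of compound 3; compound 1 differs from compound 3 in more than one place and cannot settle this.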